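The compounds below may be only part of what the source reports. "The series", "measured", "known", "first", "only" and "open" are said of these compounds alone.

Working notes on the series. Compound 3 `Fc1ccc(/C=N/Nc2nc(-c3ccc(Br)cc3)cs2)cc1F` carries a 4-bromophenyl on the shared core. In an ADME assay on HUVEC cells (Homo sapiens) for inhibition, read by MTT assay, with a stated time of 48 h (a higher number here means a weaker inhibitor, a lower number a stronger inhibitor), compound 3 gives only a limit, > 100000 nM, and not a number. Compound 1 `Fc1ccc(/C=N/Nc2nc(-c3ccc(C(F)(F)F)cc3)cs2)cc1F` gives 79500 nM in this assay. Going by the values given here, the only measured step recorded here, an at least 1.2-fold higher number from compound 1 to compound 3 (0.09 log units; that floor lies within the scatter), is bromo in place of trifluoromethyl on an aromatic carbon, and it gives no more than a lower bound because of the limit of > 100000 nM in this assay, at which 1 of the 3 values shown sits. Compound 2 `COc1cc(/C=N/Nc2nc(-c3ccc(F)c(F)c3)cs2)c(Br)c(Br)c1OC` carries the 3,4-difluorophenyl with a different remainder of the molecule and gives 54700 nM in this assay. Compound 4 `Fc1ccc(/C=N/Nc2nc(-c3ccc(F)c(F)c3)cs2)cc1F` is not yet measured. The change from compound 3 to compound 4 is 3,4-difluorophenyl in place of 4-bromophenyl on an aromatic carbon. Among the compounds with values here, no measured step covers this exchange; the step from compound 1 to compound 3 shows only that an exchange of the group on that aromatic carbon is not resolved beyond its floor, and compound 2 shows that the 3,4-difluorophenyl is compatible with a measurable number. The expected step of an at least 1.1-fold lower number from compound 3 to compound 4 (0.04 log units; that floor lies within the scatter) is therefore taken as small. Compound 4 is estimated at 90000 nM, in a range from 40000 nM to 200000 nM, with a fair chance that this assay again reports only a limit.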

Compound 4, half-maximal inhibitory concentration: 59700 nM
Compound 4: middle estimate off by 1.5-fold (0.18 log units), on the high side; the measured number falls inside the stated range.
By their numbers in this assay, from the lowest: compounds 2, 4 and 1 (each within the scatter of the next). At a limit, above all of these: compound 3.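

The exchange on this aromatic carbon gives an at least 1.6-fold lower number from compound 3 to compound 4 (0.22 log units; that floor lies within the scatter). With the 3,4-difluorophenyl on the shared core, compound 4 therefore gives a measured number in this assay, whereas the 4-bromophenyl of compound 3 gives only a limit, so the true size of this change stays unresolved: the limit of > 100000 nM in this assay, at which 1 of the 4 values shown sits. The values of compound 1 and compound 4 lie within the scatter of each other, so the trifluoromethyl-bearing phenyl and the 3,4-difluorophenyl cannot be told apart at this position.

As far as these compounds go, how far compound 3 really lies from compound 4 remains open, and so does whether any exchange here can move the number beyond the scatter. Also open, from the compounds shown here alone, is what an amine or a carboxylic acid on this phenyl, or a longer chain in its place, would do in this assay.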